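Trifluoromethyl in Place of Methyl: Compound 2 to Compound 3

The compounds below may be only part of what the source reports. "The series", "measured", "known", "first", "only" and "open" are said of these compounds alone.

Of the compounds shown here, two sharing one core have been measured so far. Compound 1 `COc1cc2cc(Oc3ccc(NC(=O)Nc4ccccc4)cc3)c(C)nc2cc1OC` carries a hydrogen at the position in question, and in a functional assay on UO-31 cells (Homo sapiens) for inhibition, read by sulforhodamine B assay, with a stated time of 48 h, tested at 10 uM (a lower number here means a stronger effect, a higher number a weaker effect of the compound at the concentration tested), compound 1 gives 65.9%. Compound 2 `COc1cc2cc(Oc3ccc(NC(=O)Nc4ccc(C)cc4)cc3)c(C)nc2cc1OC` carries a methyl there, and in this assay compound 2 gives 89.2%. Going by the values given here, on these two numbers compound 2 stands highest, the only other number being that of compound 1, and the single measured step reads a number 23.3 percentage points higher from compound 1 to compound 2 (beyond the scatter), a change beyond the scatter.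

Compound 3 `COc1cc2cc(Oc3ccc(NC(=O)Nc4ccc(C(F)(F)F)cc4)cc3)c(C)nc2cc1OC` is the next step: trifluoromethyl in place of methyl on an aromatic carbon. Among the compounds with values here, the change of compound 1 to compound 2 is the only step that bears on it, and it bears only loosely, since a methyl entering for hydrogen is not the same as a trifluoromethyl entering for methyl. Within the data shown here, with one step of modest size as the sole guide, compound 3 is expected to sit within or near the scatter of compound 2, with a slight lean toward a lower number, an expected step of a number 11.2 percentage points lower from compound 2 to compound 3 (beyond the scatter). Compound 3 is therefore estimated at 78%, with a range from 55% to 100%.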

Compound 3, a percentage reported as activity, at one concentration (the size of the read-out at that concentration, not a potency): 87.6%
Beside the measured number, compound 3's estimate is 9.6 percentage points below it; measured number inside the range.
By their numbers in this assay, from the lowest: compound 1; then compounds 3 and 2 (each within the scatter of the next).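

In this assay, trifluoromethyl in place of methyl gives a number 1.6 percentage points lower from compound 2 to compound 3 (within the scatter) and so, at this place on the ring, para to a large group, the two groups cannot be told apart, even though trifluoromethyl brings three fluorine atoms that methyl lacks. Measured against the hydrogen of compound 1, the same group gives a number 21.7 percentage points higher from compound 1 to compound 3 (beyond the scatter) and so the weaker effect first seen with methyl now appears with a second group and no longer rests on a single example. Nothing measured alongside these numbers accounts for either step.

On these data alone, only hydrogen, methyl and trifluoromethyl have been seen at this position, so it remains open whether the weaker effect holds for every group placed there or whether a group such as an amine, a methoxy, a chlorine atom or a carboxylic acid would restore or even surpass the effect of compound 1. It is also open whether trifluoromethyl and methyl would stay indistinguishable at another place on the same ring, since all of these compounds carry their group at this one position.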